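The compounds below may be only part of what the source reports. "The series", "measured", "known", "first", "only" and "open" are said of these compounds alone.

Compound 1 `O=C(NNC(=O)c1cc([N+](=O)[O-])c[nH]1)Nc1ccc([N+](=O)[O-])cc1` gives 211000 nM in an ADME assay on Vero cells (Chlorocebus sabaeus) for cytotoxicity, read by MTT assay, with a stated time of 72 h; on this read-out higher numbers stand for weaker inhibition and lower numbers for stronger inhibition. Compound 2 `Cn1cc([N+](=O)[O-])cc1C(=O)NNC(=O)Nc1ccc([N+](=O)[O-])cc1` gives 402000 nM in this assay; the change is methyl in place of hydrogen on an aromatic nitrogen, and the step is a 1.9-fold higher number from compound 1 to compound 2 (0.28 log units; within the scatter). Compound 3 `COc1ccc(OC)c(NC(=O)NNC(=O)c2cc([N+](=O)[O-])c[nH]2)c1` gives 333000 nM in this assay; the difference between the core of compound 1 and the core of compound 3 is not broken down here. Compound 4 `COc1ccc(OC)c(NC(=O)NNC(=O)c2cc([N+](=O)[O-])cn2C)c1` is not yet measured and carries methyl in place of hydrogen on an aromatic nitrogen, the same change as between compound 1 and compound 2, at the same place. Within the data shown here, the step is expected to be a 1.8-fold higher number from compound 3 to compound 4 (0.26 log units; within the scatter), comparable to a 1.9-fold higher number from compound 1 to compound 2 (0.28 log units; within the scatter), because that earlier step a 1.9-fold higher number from compound 1 to compound 2 (0.28 log units; within the scatter) is the only measured instance of this change. Compound 4 is therefore estimated at 600000 nM in this assay, between 250000 nM and 1300000 nM.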

Compound 4, half-maximal inhibitory concentration: 429000 nM
Compound 4: the middle estimate sits 1.4-fold (0.15 log units) above what was measured; measured number inside the range.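

On the core of compound 3, methyl in place of hydrogen on an aromatic nitrogen gives a 1.3-fold higher number from compound 3 to compound 4 (0.11 log units; within the scatter) in this assay. Compared with the earlier step, the change carries over to the second core with no difference that can be told apart: the same change on two cores in this assay, a 1.9-fold higher number (0.28 log units; within the scatter) from compound 1 to compound 2 and a 1.3-fold higher number (0.11 log units; within the scatter) from compound 3 to compound 4, 1.5-fold (0.17 log units) apart, within the scatter of two such steps Each step lies within the scatter on its own, and these two pairs therefore show agreement between two cores, neither a measurable effect of the methyl nor a rule for other cores in the series.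

Still open, as far as these compounds go, is whether a longer chain on the same aromatic nitrogen would give a step beyond the scatter. Also open, from the compounds shown here alone, is how an amine in place of the nitro group on that ring would read in this assay.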